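Widening a Small Ring on Compound 3

The compounds below may be only part of what the source reports. "The series", "measured", "known", "first", "only" and "open" are said of these compounds alone.

Of the compounds shown here, three sharing one core have been measured in an assay on membranes from HEK293 cells for displacement of a labelled ligand from adenosine receptor A2b (Homo sapiens), read by scintillation counting, with a stated time of 30 min; on this read-out lower numbers stand for stronger inhibition and higher numbers for weaker inhibition. Compound 1 `CC1=C(C(=O)C2CC2)C(c2ccco2)NC(=O)N1` gives 1060 nM, and compound 2 `CCCC(=O)C1=C(C)NC(=O)NC1c1ccco1` gives 807 nM. Compound 3 `CC1=C(C(=O)OCC2CC2)C(c2ccco2)NC(=O)N1` gives 138 nM, the lowest of the three numbers, standing clear of both others: the measured steps were a 7.7-fold lower number from compound 1 to compound 3 (0.89 log units; beyond the scatter) and a 5.8-fold lower number from compound 2 to compound 3 (0.77 log units; beyond the scatter), in each case with cyclopropylmethoxy replacing a group on the carbonyl carbon.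

Compound 4 `CC1=C(C(=O)OCC2CCC2)C(c2ccco2)NC(=O)N1` has not yet been measured. It differs from compound 3 by cyclobutyl in place of cyclopropyl on a saturated chain carbon bound to an oxygen next to a carbonyl group. Among the compounds with values here, no measured step changes ring size at this place. The nearest comparison is a 1.3-fold lower number from compound 1 to compound 2 (0.12 log units; within the scatter), where a small carbon ring gave way to a short chain of similar size on the carbonyl carbon and the number hardly moved. The two larger steps concern the carbonyl substituent itself and say little about a ring one atom bigger further out. A step no larger than the usual scatter is therefore expected, in either direction. Compound 4 is estimated at 150 nM, between 60 nM and 400 nM, which would mean an expected 1.1-fold higher number from compound 3 to compound 4 (0.04 log units; within the scatter).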

Compound 4, inhibition constant: 561 nM
Estimate against measurement, compound 4: 3.7-fold (0.57 log units) below, and the stated range ends below it.
By their numbers in this assay, from the lowest: compound 3; then compounds 4, 2 and 1 (each within the scatter of the next).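

In this assay, ring size at this place matters: adding one ring carbon, cyclobutyl in place of cyclopropyl, gives a 4.1-fold higher number from compound 3 to compound 4 (0.61 log units; beyond the scatter) as a step beyond the scatter. The low number of compound 3 therefore depends on cyclopropylmethoxy itself, and a similar group on the carbonyl carbon does not automatically share it, since cyclobutylmethoxy gives only a 1.4-fold lower number from compound 2 to compound 4 (0.16 log units; within the scatter) and a 1.9-fold lower number from compound 1 to compound 4 (0.28 log units; within the scatter) and both of these steps lie within the scatter. Nothing available here accounts for how one extra ring carbon produces this change.

Still open, from the compounds shown here alone, is whether cyclopentyl at this place would raise the number further or leave it unchanged. It is also unclear whether an open chain such as isobutyl could match cyclopropylmethoxy, or whether the small ring is needed.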